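Substance-P binding series: compound 4 expected

The source may hold more compounds than are shown below. What is called first, only, known or untested is meant among the compounds shown, and "the series" means these compounds.

Three spirocyclic amides on the shared core have numbers in an assay on isolated protein for inhibition of Substance-P receptor (Cavia porcellus), tested at 1 ug/mL; on this read-out lower numbers stand for less inhibition and higher numbers for more inhibition at the one concentration tested (going by the name of the read-out). Compound 1 `COc1cc(C(=O)N2CO[C@](CCN3CCC(n4c(O)nc5ccccc54)CC3)(c3ccc(Cl)c(Cl)c3)C2)cc(OC)c1OC` gives 100% in this assay. Compound 3 `COc1cc(C(=O)N2CO[C@](CCN3CCN(c4ncccn4)CC3)(c3ccc(Cl)c(Cl)c3)C2)cc(OC)c1OC` gives 100% in this assay, level with compound 1 at the digits shown, and the two together stand at the top of the three numbers. For the measured compounds named here, compound 2 `COc1cc(C(=O)N2CO[C@](CCN3CCC4(CC3)CN(c3ccccc3)C(=O)O4)(c3ccc(Cl)c(Cl)c3)C2)cc(OC)c1OC` gives 86% in this assay, a number lower than that of compound 1 by a gap beyond the usual scatter; no single-change step joins any two of these measured compounds, so only the values themselves can be compared.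

Compound 4 `COc1cc(C(=O)N2CO[C@](CCN3CCC(C(=O)Nc4ccccc4)CC3)(c3ccc(Cl)c(Cl)c3)C2)cc(OC)c1OC` has not yet been measured in this assay. It differs from compound 1 by phenylcarbamoyl in place of 2-hydroxy-1H-benzimidazol-1-yl on a saturated ring carbon, a change made on the same saturated ring carbon that carries the large group in compound 1. The numbers of compounds 1 and 3 are the highest of the three and that of compound 2 is the lowest at the single concentration tested, so the expectation is a step of small size, downward if anything, and possibly none beyond the scatter. Because compound 1 gives 100%, compound 4 is estimated at 90%, within 70% to 100%, which means an expected step of a number 10 percentage points lower from compound 1 to compound 4 (within the scatter) in this assay.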

Compound 4, a percentage reported as inhibition, at one concentration (the size of the read-out at that concentration, not a potency): 44%
For compound 4 the middle estimate is 46 percentage points above the measured one; the whole stated range lies above it.
By their numbers in this assay, from the lowest: compound 4; then compound 2; then compounds 1 and 3 (each within the scatter of the next).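

In this assay, phenylcarbamoyl in place of 2-hydroxy-1H-benzimidazol-1-yl on the saturated ring carbon gives a number 56 percentage points lower from compound 1 to compound 4 (beyond the scatter), the only single-change step among the compounds shown. This position on the six-membered non-aromatic ring is therefore not indifferent to its substituent: the two groups are close in heavy-atom count, and each carries a six-membered aromatic ring of carbon only and a hydrogen-bond donor, yet the read-out separates them widely. The counted differences are the five-membered aromatic ring with 2 hetero atoms in the group that leaves and the double bond outside aromatic rings in the group that enters, but nothing available explains the drop.

This one step cannot separate the loss of the five-membered aromatic ring from the arrival of the open amide, and it gives no read on how compound 4 would behave away from the single concentration tested. Also open, as far as these compounds go, is whether a methyl group on the amide nitrogen, a benzyl group in place of the phenyl, or a simple carboxylic acid or primary amine on this ring carbon would lie nearer to compound 1 or to compound 4.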